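The source may hold more compounds than are shown below. What is called first, only, known or untested is meant among the compounds shown, and "the series" means these compounds.

Measured so far in a functional assay on the whole organism (Tail, strain ICR) with Mus musculus as the target, in the tail flick test, with a stated time of 120 min, at a dose of 25 umol/kg by the oral route; on this read-out higher numbers stand for a stronger effect at the one dose given and lower numbers for a weaker effect:

compound 1 `O=C(CN(c1nc(Cl)nc2[nH]cnc12)C1CC1)N[C@@H](CO)C(=O)OCc1ccccc1`, giving 34.5%
compound 2 `O=C(CN(c1nc(Cl)nc2[nH]cnc12)C1CC1)N[C@@H](CO)C(=O)O`, giving 39%
compound 3 `NC(=O)C[C@H](NC(=O)CN(c1ncnc2c1ncn2C1CCCCO1)C1CC1)C(=O)OCc1ccccc1`, giving 29.2%

Compound 1 stands second highest of the three numbers, but its gap to compound 2 is within the scatter and so is its gap to compound 3, so the three measured compounds cannot be told apart on this read-out. Among the compounds with values here, the one step between compounds differing in a single place is a number 4.5 percentage points higher from compound 1 to compound 2 (within the scatter), a change at the ester oxygen that does not touch the side chain altered here.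

Compound 4 `NC(=O)C[C@H](NC(=O)CN(c1nc(Cl)nc2[nH]cnc12)C1CC1)C(=O)OCc1ccccc1` is compound 1 with the change (carbamoyl in place of hydroxy on a saturated chain carbon, two bonds along the chain from an amide-type nitrogen and a carbonyl carbon). Within the data shown here, no measured step covers this change. Compound 3 carries a carbamoylmethyl chain, but it differs from compound 1 at the core as well, so its value and that of compound 1 can only be set side by side: the two numbers lie within the scatter of each other. With nothing in the measured steps pointing either way, the expectation for this assay is a step of no size beyond the scatter, a number 1.5 percentage points lower from compound 1 to compound 4 (within the scatter).

Compound 4 is therefore estimated at 33%, with a range from 20% to 47%.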

Compound 4, a percentage reported as activity, at one dose (the size of the read-out at that dose, not a potency): 15.1%
Compound 4: middle estimate off by 17.9 percentage points, on the high side; measured number below the stated range.
By their numbers in this assay, from the lowest: compound 4; then compounds 3, 1 and 2 (each within the scatter of the next).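

In this assay this saturated chain carbon proves sensitive to its substituent: hydroxymethyl to carbamoylmethyl gives a number 19.4 percentage points lower from compound 1 to compound 4 (beyond the scatter) and is the only listed step beyond the scatter, while the single earlier step, at the ester oxygen, stayed within it. Hydroxy and carbamoyl have the same counted hydrogen-bond donors and acceptors and no net charge, so the step arises with those counts unchanged; the counted differences are the larger heavy-atom count and the double bond of carbamoyl. The data available here give no measured basis for explaining the step.

Going by these compounds, it remains open whether the change would have the same size with the free acid of compound 2 in place of the benzyl ester, and whether the lower number belongs to carbamoyl itself or simply to the longer substituent. A carboxylic acid or an amine at the end of this chain, set against a plain ethyl chain on the same carbon, would help separate these readings.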